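Benzylselanyl for methylsulfanyl on a nitrothiophene acylamidine core

This account rests on a few compounds, and the source may have more. Where it says the series, first, only, none or still open, it means among the compounds named here.

Compound 1 `CS/C(=N\C(=O)c1csc([N+](=O)[O-])c1)NC(=O)c1csc([N+](=O)[O-])c1` is the strongest growth inhibitor of the three measured compounds; in an ADME assay on MCF-10A cells (Homo sapiens) for cytotoxicity, read by MTT assay, with a stated time of 72 h (a lower number here means a stronger inhibitor of growth, a higher number a weaker inhibitor of growth), compound 1 gives 1550 nM. Compound 3 `CS/C(=N\C(=O)c1cccs1)NC(=O)c1cccs1` shares the same arrangement around the carbon with a double bond to nitrogen, but its cores differ from those of compound 1 in a way that is not broken down here; in this assay compound 3 gives 19700 nM. Compound 2 `O=C(/N=C(/NC(=O)c1cccs1)[Se]Cc1ccccc1)c1cccs1` is made from compound 3 by one change, (a group of 8 heavy atoms (7 carbon, 1 selenium; one six-membered aromatic ring of carbon only) in place of a group of 2 heavy atoms (1 carbon, 1 sulfur; no ring), on a carbon with a double bond to nitrogen), and in this assay compound 2 gives 72500 nM, a step of a 3.7-fold higher number from compound 3 to compound 2 (0.57 log units; beyond the scatter).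

Compound 4 `O=C(/N=C(/NC(=O)c1csc([N+](=O)[O-])c1)[Se]Cc1ccccc1)c1csc([N+](=O)[O-])c1` has not been measured. It arises from compound 1 by the same change, (a group of 8 heavy atoms (7 carbon, 1 selenium; one six-membered aromatic ring of carbon only) in place of a group of 2 heavy atoms (1 carbon, 1 sulfur; no ring), on a carbon with a double bond to nitrogen), at a place described in identical words. The change was seen only once, on compound 3, so the expectation rests on that single step. Within the data shown here, compound 4 is therefore expected to be a weaker growth inhibitor than compound 1 by about a 3.7-fold higher number from compound 1 to compound 4 (0.57 log units; beyond the scatter), because the step of a 3.7-fold higher number from compound 3 to compound 2 (0.57 log units; beyond the scatter) is the only guide. In this assay compound 4 is estimated at 5700 nM, with a plausible range from 2000 nM to 16000 nM.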

Compound 4, concentration for 50% growth inhibition: 24400 nM
For compound 4 the middle estimate is 4.3-fold (0.63 log units) below the measured one; measured number above the stated range.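

In this assay, putting the benzylselanyl group in place of methylsulfanyl gives a 16-fold higher number from compound 1 to compound 4 (1.20 log units; beyond the scatter) and so weakens growth inhibition, the same direction as on the other core. The size of the step, however, does not carry over from one core to the other: the same change on two cores in this assay, a 3.7-fold higher number (0.57 log units; beyond the scatter) from compound 3 to compound 2 and a 16-fold higher number (1.20 log units; beyond the scatter) from compound 1 to compound 4, 4.3-fold (0.63 log units) apart, beyond the scatter of two such steps. The direction therefore held on both cores, but a step measured on one core proved a poor guide to its size on the other, and two cores cannot show which difference between them sets the gap or how the change would behave on a third core.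

This change replaces sulfur with selenium and methyl with benzyl at once, so the compounds shown leave open which part accounts for the rise in the number; a benzylsulfanyl or a methylselanyl group on the same carbon would separate the two. Also open, on these data alone, is how a group without a ring, such as a longer chain, would behave at this place on either core.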